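From compound 3 to compound 4: one aryl group for another

The source may report more compounds than this note shows. Statements on the series, on what has been measured and on what is new or still open speak of the compounds shown alone.

Measured in a physicochemical assay for solubility, in phosphate buffer, measured as kinetic solubility, at pH 7.4; on this read-out lower numbers stand for lower solubility and higher numbers for higher solubility:
- Compound 1 `Cc1oc(-c2c(Br)cccc2Br)nc1CN1CCC(C(=O)NCCCN2C[C@H](C)C[C@H](C)C2)CC1`: 62.4 ug/mL
- Compound 2 `Cc1oc(-c2c(Cl)cccc2Br)nc1CN1CCC(C(=O)NCCCN2C[C@H](C)C[C@H](C)C2)CC1`: > 83 ug/mL, a limit of the assay
- Compound 3 `CCc1ccccc1-c1nc(CN2CCC(C(=O)NCCCN3C[C@H](C)C[C@H](C)C3)CC2)c(C)o1`: 55.9 ug/mL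

Compound 3 stands level with compound 1 in this assay, as the measured step shows: a 1.1-fold lower number from compound 1 to compound 3 (0.05 log units; within the scatter). Its relation to compound 2 is known only against a limit: an at least 1.4-fold lower number from compound 2 to compound 3 (0.17 log units; that floor lies within the scatter).

Compound 4 `Cc1ccc(-c2nc(CN3CCC(C(=O)NCCCN4C[C@H](C)C[C@H](C)C4)CC3)c(C)o2)c(C)c1` carries 2,4-dimethylphenyl in place of 2-ethylphenyl on an aromatic carbon. The two compounds have the same atoms, joined differently.

The measured steps that bear on this change are those made at the same aromatic carbon, and neither of them leaves the scatter. The exchange of one halogen for another is no larger: an at least 1.3-fold higher number from compound 1 to compound 2 (0.12 log units; that floor lies within the scatter). A swap between two groups of equal atom count is therefore expected to give no step beyond the scatter. The estimated step is a 1.1-fold higher number from compound 3 to compound 4 (0.03 log units; within the scatter). For compound 4 the expected value is 60 ug/mL, with an estimated range of 32 ug/mL to 100 ug/mL.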

Compound 4, solubility: > 71 ug/mL
Compound 4 was reported as a limit; the forecaster's own chance of this, stated with the estimate: 20%; middle value at least 1.1-fold (0.07 log units) away from the limit.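

Compound 4 is known in this assay only through a limit: the limit of > 71 ug/mL in this assay, at which 1 of the 4 values shown sits. The exchange of 2-ethylphenyl for 2,4-dimethylphenyl gives an at least 1.2-fold higher number from compound 3 to compound 4 (0.10 log units; that floor lies within the scatter), and the exchange of 2,6-dibromophenyl for 2,4-dimethylphenyl gives an at least 1.1-fold higher number from compound 1 to compound 4 (0.05 log units; that floor lies within the scatter), so neither floor establishes a change beyond the scatter. Compound 2 had been the only compound shown at a limit, and now an aryl ring of carbon only, with no halogen, at this position also gives one, while the step between compound 2 and compound 4 cannot be read, both values being limits.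

On these data alone, how far the true value of compound 4 lies from its limit remains open. So does the reading for a pyridyl or 4-methoxyphenyl group at this position.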